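Sulfonyl substituent change on a dihydropyrazole series

This account rests on a few compounds, and the source may have more. Where it says the series, first, only, none or still open, it means among the compounds named here.

Measured compounds:
compound 1 `CN1CCN(c2ccc(C3=NN(C(=O)CCCl)C(c4ccc(N(C)C)cc4)C3)cc2)CC1` — 2.4%
compound 2 `CN1CCN(c2ccc(C3=NN(S(C)(=O)=O)C(c4ccc(N(C)C)cc4)C3)cc2)CC1` — 0.6%

The account follows compound 2, whose structure is `CN1CCN(c2ccc(C3=NN(S(C)(=O)=O)C(c4ccc(N(C)C)cc4)C3)cc2)CC1`. In a functional assay on MDA-MB-231 cells (Homo sapiens) for inhibition, read by sulforhodamine B assay, tested at 10 uM (on this read-out lower numbers stand for less inhibition and higher numbers for more inhibition at the one concentration tested (going by the name of the read-out)), compound 2 gives 0.6%, the lowest of the two numbers at hand, though its nearest neighbour, compound 1, lies within the scatter: a number 1.8 percentage points lower from compound 1 to compound 2 (within the scatter). Both measured compounds therefore give low numbers in this assay, and the two numbers are level within the scatter.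

Compound 3 `CN1CCN(c2ccc(C3=NN(S(=O)(=O)c4ccc(Br)cc4)C(c4ccc(N(C)C)cc4)C3)cc2)CC1` differs from compound 2 by 4-bromophenyl in place of methyl on a sulfonyl sulfur, that is, the change from methylsulfonyl to (4-bromophenyl)sulfonyl on the sulfonyl sulfur next to the ring sulfonamide nitrogen. Among the compounds with values here, no measured step touches this sulfonyl substituent; the only step known, from the (2-chloroethyl)carbonyl of compound 1 to the methylsulfonyl of compound 2, stayed within the scatter. Within the data shown here, with the two measured values so close and no step bearing directly on the new group, the expectation for compound 3 is a step of a number 4.4 percentage points higher from compound 2 to compound 3 (within the scatter), none beyond the scatter. Compound 3 is thus estimated at 5%, within a range from -8% to 25%.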

Compound 3, a percentage reported as inhibition, at one concentration (the size of the read-out at that concentration, not a potency): 23.7%
Compound 3: the middle estimate sits 18.7 percentage points below what was measured; the measured number falls inside the stated range.
By their numbers in this assay, from the lowest: compounds 2 and 1 (each within the scatter of the next); then compound 3.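

In this assay, within the data shown here, the group on the sulfonyl sulfur proves to be a place where the number can move beyond the scatter: 4-bromophenyl in place of methyl gives a number 23.1 percentage points higher from compound 2 to compound 3 (beyond the scatter), whereas the only earlier step stayed within it. Placing (4-bromophenyl)sulfonyl instead of (2-chloroethyl)carbonyl on the amine nitrogen in a ring likewise gives a number 21.3 percentage points higher from compound 1 to compound 3 (beyond the scatter), so compound 3 stands apart from both compound 1 and compound 2, which remain level with each other. Nothing at hand accounts for the higher number that comes with the 4-bromophenyl group.

The compounds shown leave open whether this step belongs to the phenyl ring or to its bromine, a question that a plain phenyl, a 4-chlorophenyl or a 4-methoxyphenyl on the sulfonyl sulfur would address. Also open, on these data alone, is whether the step would persist if a morpholine took the place of the methylpiperazine in the shared core, or a methoxy group the place of its dimethylamino group.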